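The compounds below may be only part of what the source reports. "The series", "measured", "known", "first", "only" and "open" are said of these compounds alone.

Working notes on the series. In a functional assay on MKN-45 cells (Homo sapiens) for cytotoxicity, read by MTT assay, with a stated time of 72 h (a higher number here means a weaker inhibitor, a lower number a stronger inhibitor), compound 1 `CN(C)CCn1cnnc1-c1cc(Oc2ccc(NC(=O)N/N=C/c3ccc(Cl)cc3Cl)cc2F)ccn1` gives 750 nM, and compound 2 `CN(C)CCn1cnnc1-c1cc(Oc2ccc(NC(=O)N/N=C/c3ccc(F)cc3F)cc2F)ccn1` gives 810 nM; the step of a 1.1-fold higher number from compound 1 to compound 2 (0.03 log units; within the scatter). Compound 3 `CN(C)CCn1cnnc1-c1cc(Oc2ccc(NC(=O)N/N=C/c3c(O)ccc4ccccc34)cc2F)ccn1` gives 2020 nM, the highest number of the three, with both steps of a 2.7-fold higher number from compound 1 to compound 3 (0.43 log units; beyond the scatter) and a 2.5-fold higher number from compound 2 to compound 3 (0.40 log units; beyond the scatter) beyond the scatter. Compound 4 `CN(C)CCn1cnnc1-c1cc(Oc2ccc(NC(=O)N/N=C/c3ccc(O)cc3O)cc2F)ccn1` is not yet measured. Change from compound 3: 2,4-dihydroxyphenyl in place of 2-hydroxynaphthalen-1-yl on a carbon with a double bond to nitrogen. Going by the values given here, the steps that bear on this position are those into compound 3 from compound 1 and compound 2, each modest, and both show a 2,4-dichlorophenyl or 2,4-difluorophenyl ring giving a lower number than 2-hydroxynaphthalen-1-yl. For compound 4 a modest lowering is expected, step a 1.8-fold lower number from compound 3 to compound 4 (0.26 log units; within the scatter). Compound 4 is estimated at 1100 nM, range 450 nM to 2800 nM.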

Compound 4, half-maximal inhibitory concentration: 2860 nM
Compound 4: the middle estimate sits 2.6-fold (0.41 log units) below what was measured; measured number outside the range, above it.
By their numbers in this assay, from the lowest: compounds 1 and 2 (each within the scatter of the next); then compounds 3 and 4 (each within the scatter of the next).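

In this assay, 2,4-dihydroxyphenyl in place of 2-hydroxynaphthalen-1-yl gives a 1.4-fold higher number from compound 3 to compound 4 (0.15 log units; within the scatter), so dropping from two aromatic rings to one while keeping a hydroxyl-bearing group leaves no readable difference at this position. The gap to the halogen-bearing rings holds for this second hydroxyl-bearing group, with a 3.5-fold higher number from compound 2 to compound 4 (0.55 log units; beyond the scatter) and a 3.8-fold higher number from compound 1 to compound 4 (0.58 log units; beyond the scatter). No measurement at hand accounts for that gap. Open, from the compounds shown here alone, is whether a phenyl ring carrying methoxy groups or an amine falls with compound 1 and compound 2 or with compound 3 and compound 4.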